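Mirror-image pyrrolidine triazoles against alpha-galactosidase

The source may hold more compounds than are shown below. What is called first, only, known or untested is meant among the compounds shown, and "the series" means these compounds.

Working notes on a small set of iminosugar-type triazoles. The read-out throughout is an assay on isolated protein for inhibition of alpha-galactosidase (Coffea arabica), with stated times of 5 min and 20 min, tested at 1 mM; a lower number here means less inhibition, a higher number more inhibition at the concentration tested (going by the name of the read-out). Compound 1, `O[C@@H]1[C@@H](c2cn(Cc3ccccc3)nn2)NC[C@@H]1O`, is reported in this assay as "not active" (no number reported), so no single number stands for it and it anchors the low end of what has been seen. Compound 2, `O[C@@H]1[C@H](O)CN[C@@H]1Cn1cc(-c2ccccc2)nn1`, is a ring-expanded positional variant with the triazole attached through a methylene. In this assay compound 2 gives <= 50%, which is a limit of the assay and not a number. As evidence on the values shown there is only (the limit of <= 50% in this assay, at which 1 of the 2 values shown sits). Within the data shown here, no step between two measured compounds exists here, so both data points sit at or below the threshold of detection.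

Compound 3, `O[C@@H]1[C@H](O)CN[C@H]1c1cn(Cc2ccccc2)nn1`, is the next structure to be measured. Relative to compound 1 the change is the two compounds have the same atoms and bonds and differ only in configuration as drawn: 3 of 3 stereo elements differ (all stereocentres are inverted: mirror images); a stereocentre at a saturated ring carbon is drawn R in compound 1 and S in compound 3; a stereocentre at a saturated ring carbon is drawn S in compound 1 and R in compound 3; a stereocentre at a saturated ring carbon is drawn R in compound 1 and S in compound 3. Since compound 1 gives no measurable inhibition, no step beyond the scatter is expected in either direction for compound 3, and a further limit-only report is the likeliest outcome. Compound 3 is therefore expected to give an inhibition near 15%, estimated between 0% and 50%.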

Compound 3, a percentage reported as inhibition, at one concentration (the size of the read-out at that concentration, not a potency): "not active" (no number reported)
No number was reported for compound 3; no gap can be computed for the estimate.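

In this assay compound 1 gives "not active" (no number reported) and compound 3 gives "not active" (no number reported), so no step can be read between these two mirror images. The compounds shown leave open whether the configuration of the shared core changes inhibition at all.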